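Fluoro to methoxy on a compound at the limit

The compounds below may be only part of what the source reports. "The series", "measured", "known", "first", "only" and "open" are said of these compounds alone.

Compound 1 `Cc1cc(NC(=O)Nc2ccccc2N)c2ccccc2n1` gives > 25000 nM as a limit
Compound 2 `Cc1cc(NC(=O)Nc2cccc(F)c2)c2ccccc2n1` gives > 25000 nM as a limit
Compound 3 `Cc1cc(NC(=O)Nc2ccc(O)cc2)c2ccccc2n1` gives > 25000 nM as a limit

In an ADME assay on HEK293 cells (Homo sapiens) for cytotoxicity, with a stated time of 72 h (on this read-out higher numbers stand for an effect only at larger amounts of compound and lower numbers for an effect already at smaller amounts), compound 2 gives > 25000 nM as its result, which is a limit and not a number. It has no company other than limits, since all three measured compounds share one reading (the limit of > 25000 nM in this assay, at which 3 of the 3 values shown sit) in this test.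

Compound 4 `COc1cccc(NC(=O)Nc2cc(C)nc3ccccc23)c1` differs from compound 2 by methoxy in place of fluoro on an aromatic carbon, meta to a large group (methoxy in place of fluoro on an aromatic carbon) in the structure.

Among the compounds with values here, three measured steps bear on this, all swaps of the group on an amide-type nitrogen: (a step that the two limits leave unreadable from compound 1 to compound 2), (a step that the two limits leave unreadable from compound 1 to compound 3) and (a step that the two limits leave unreadable from compound 2 to compound 3). None of them has a readable size, so they offer no measured size to carry over. No step beyond the usual scatter is expected in this assay and no direction can be foreseen. The expected change is (a step that the limit leaves unreadable from compound 2 to compound 4) on this estimate. Compound 4 is estimated at 30000 nM with an expected range from 15000 nM to 60000 nM and will most likely be reported only as a limit.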

Compound 4, half-maximal effective concentration: > 25000 nM
Compound 4 ended at the assay's limit; the forecaster's own chance of this, stated with the estimate: 85%; the middle value lies beyond the limit too.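

Compound 2 and compound 4 both end at a limit rather than a number, so the step between them cannot be read. All the compounds share that reading: the limit of > 25000 nM in this assay, at which 4 of the 4 values shown sit.

The compounds shown leave open at what amount, if any, each would produce an effect in this assay.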